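Bromo for Fluoro on the Sulfonyl Aryl Ring

The compounds below may be only part of what the source reports. "The series", "measured", "known", "first", "only" and "open" are said of these compounds alone.

Measured so far:
compound 1, `CN1CCN(c2ccc(C3=NN(C(=O)/C=C/c4ccccc4)C(c4ccc(N(C)C)cc4)C3)cc2)CC1`, 35.9%
compound 2, `CN1CCN(c2ccc(C3=NN(S(=O)(=O)c4ccc(F)cc4)C(c4ccc(N(C)C)cc4)C3)cc2)CC1`, 15.7%

For the measured compounds named here, in a functional assay on MDA-MB-231 cells (Homo sapiens) for inhibition, read by sulforhodamine B assay, tested at 10 uM (on this read-out higher numbers stand for more inhibition at the one concentration tested (going by the name of the read-out) and lower numbers for less inhibition), compound 2 stands lowest of the two numbers known. Going by the values given here, its only neighbour is compound 1, which in this assay gives 35.9%, and the one step that connects them is a number 20.2 percentage points lower from compound 1 to compound 2 (beyond the scatter), a change on the amine nitrogen in the ring of the shared core.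

Compound 3, `CN1CCN(c2ccc(C3=NN(S(=O)(=O)c4ccc(Br)cc4)C(c4ccc(N(C)C)cc4)C3)cc2)CC1`, differs from compound 2 elsewhere: bromo in place of fluoro on an aromatic carbon. Among the compounds with values here, no measured step touches that aromatic carbon, so the single known step gives no direct guidance; it shows only that a change on the ring nitrogen moved the read-out modestly, while the halogen on the sulfonyl aryl ring has never been varied here. Within the data shown here, with no step bearing on this change, the expectation is that compound 3 stays close to compound 2, with the step from compound 2 to compound 3 expected to be a number 2.3 percentage points higher from compound 2 to compound 3 (within the scatter), not beyond the scatter. The estimate for compound 3 in this assay is therefore 18%, with a range from 4% to 36%.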

Compound 3, a percentage reported as inhibition, at one concentration (the size of the read-out at that concentration, not a potency): 23.7%
For compound 3 the middle estimate is 5.7 percentage points below the measured one, and the stated range covers the measured number.
By their numbers in this assay, from the lowest: compounds 2 and 3 (each within the scatter of the next); then compound 1.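

In this assay, for the compounds shown here, bromo in place of fluoro is the first change at this aromatic carbon, para to a large group, and it gives a number 8 percentage points higher from compound 2 to compound 3 (within the scatter), so the two halogens cannot be told apart on this read-out. The earlier step showed a lower number for one sulfonyl compound only, and the bromo compound now gives a second case: a number 12.2 percentage points lower from compound 1 to compound 3 (beyond the scatter), so with either halogen the (4-halophenyl)sulfonyl compound stays beyond the scatter from the (2-phenylethenyl)carbonyl compound. Nothing available explains these numbers.

With only two halogens shown, it remains open whether a quite different group on this aromatic carbon, such as a methoxy group, a nitrile or an amine, would separate from them on this read-out. Each number also comes from a single concentration, so the compounds shown leave open how the inhibition of any of them would vary with dose, and whether the same near-match between fluoro and bromo would hold at other concentrations.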